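The source may hold more compounds than are shown below. What is called first, only, known or untested is meant among the compounds shown, and "the series" means these compounds.

Of the compounds shown here, two have been measured in an ADME assay on microsomes from liver (Mus musculus, strain CD-1) for metabolic stability, read by LC-MS, tested at 2 uM; a higher number here means that the compound lasts longer, a lower number that the compound disappears faster. Compound 1 `Cn1ccc2ccc(-c3cc(Nc4cnccc4C(=O)NCc4cncnc4)cc4nccnc34)cc21` gives 0.4 h. Compound 2 `CN1CCC(NC(=O)c2ccncc2Nc2cc(-c3ccc4sc(N)nc4c3)c3nccnc3c2)C1` gives > 1 h, which is a limit of the assay and not a number. Where compound 2 stands is thus known only as the limit of > 1 h in this assay, at which 1 of the 2 values shown sits.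

Compound 3 `CN1CCC(NC(=O)c2ccncc2Nc2cc(-c3cc(F)c4ccn(C)c4c3)c3nccnc3c2)C1` departs from compound 2 in one place, with 4-fluoro-1-methyl-1H-indol-6-yl in place of 2-amino-1,3-benzothiazol-5-yl on an aromatic carbon. Among the measured compounds shown here, no measured pair isolates this change, so any forecast is loose. For the measured compounds named here, compound 1, whose group at this place resembles the entering one, gives 0.4 h, and this is the only guide to direction. A shorter half-life in this assay is therefore expected, with an at least 1.4-fold lower number from compound 2 to compound 3 (0.15 log units; that floor lies within the scatter) estimated as a moderate fall. For compound 3 the estimated half-life is 0.7 h, with an expected range of 0.3 h to 1.4 h.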

Compound 3, half-life in the Mus musculus assay: > 1 h
Compound 3 gave a limit, no number; the forecaster's own chance of this, stated with the estimate: 25%; middle value at least 1.4-fold (0.15 log units) away from the limit.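

In the Mus musculus assay compound 2 gives > 1 h, which is a limit of the assay and not a number. In the Mus musculus assay compound 3 gives > 1 h, which is also a limit of the assay and not a number. Among the compounds shown here, no step between the two compounds can be read: the limit of > 1 h in the Mus musculus assay, at which 2 of the 3 values shown sit. Whether 4-fluoro-1-methyl-1H-indol-6-yl in place of 2-amino-1,3-benzothiazol-5-yl changes the half-life at all remains open. In a physicochemical assay for solubility, read by spectrophotometry, measured as kinetic solubility, at pH 8, tested at 500 uM (a lower number here means a less soluble compound, a higher number a more soluble compound), compound 2 gives 241 ug/mL and compound 3 gives 185 ug/mL, two values within the scatter of each other.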